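The compounds below may be only part of what the source reports. "The series", "measured", "known", "first", "only" and "open" are said of these compounds alone.

In an in vitro ADME assay on microsomes from liver (Mus musculus) for pharmacokinetics, read by LC-MS, with a stated time of 10 min, tested at 1 uM (a higher number here means faster removal of the compound, a lower number slower removal), two compounds that share one core have been measured so far. Compound 1 (`Nc1ccccc1NC(=O)/C=C/c1ccc([C@H]2CN(C3COC3)C[C@@H]2C(=O)Nc2ccc(Cl)cc2)cc1`) gives 42 mL/min/kg and compound 2 (`N#CCN1C[C@H](C(=O)Nc2ccc(Cl)cc2)[C@@H](c2ccc(/C=C/C(=O)Nc3ccccc3N)cc2)C1`) gives 51 mL/min/kg, so compound 2 stands level with compound 1 within the scatter. Compound 3 (`CCN(CC)C(=O)N1C[C@H](C(=O)Nc2ccc(Cl)cc2)[C@@H](c2ccc(/C=C/C(=O)Nc3ccccc3N)cc2)C1`) keeps the shared core and differs from compound 2 only on the amine nitrogen in a ring, where diethylcarbamoyl comes in place of cyanomethyl: diethylcarbamoyl in place of cyanomethyl on an amine nitrogen in a ring. Among the compounds with values here, one measured step bears on this site. Cyanomethyl in place of oxetan-3-yl gave a 1.2-fold higher number from compound 1 to compound 2 (0.08 log units; within the scatter), which lies within the scatter. Within the data shown here, that single step is small, but the data hold no measured compound with a diethylcarbamoyl group on this nitrogen, so it offers only a weak guide. No step beyond the scatter is therefore expected in this assay. The expected size is a 1.1-fold higher number from compound 2 to compound 3 (0.06 log units; within the scatter), a slight lean towards a higher number with little support behind it. Compound 3 is estimated at 58 mL/min/kg, with the measurement expected to fall between 32 mL/min/kg and 100 mL/min/kg.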

Compound 3, clearance: 83 mL/min/kg
Compound 3: middle estimate off by 1.4-fold (0.16 log units), on the low side; the range from low to high includes it.
By their numbers in this assay, from the lowest: compounds 1, 2 and 3 (each within the scatter of the next).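

In this assay, diethylcarbamoyl on the amine nitrogen brings a 1.6-fold higher number from compound 2 to compound 3 (0.21 log units; within the scatter) and a 2.0-fold higher number from compound 1 to compound 3 (0.30 log units; within the scatter), so compounds 1, 2 and 3 remain level. This shows more than the earlier pair could: the number stays within the scatter when cyanomethyl, with its 3 heavy atoms and triple bond, gives way to a group of 7 heavy atoms that places a carbonyl on this nitrogen. Across these three compounds, then, neither the size of the group nor the presence of that double bond separates the numbers by more than the scatter, and no compound here goes against this. Nothing shown here explains the size of either step.

The three compounds leave open whether an acetyl group, a simple ethyl chain, a carboxylic acid or a primary amine on a longer chain at this nitrogen would stay level with them or move the number beyond the scatter. They also leave open whether the same substituents would behave alike if the (4-chlorophenyl)carbamoyl group carried another halogen, such as fluorine, in place of chlorine.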